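A Chloro-to-Methoxy Swap at the Assay Limit

A few compounds are considered here, and "the series" means these few. Any claim that something is new, unique, unknown or untested is made for them only; others in the source may bear on it.

Of the compounds shown here, three have been tested in a functional assay on A2780 cells (Homo sapiens) for inhibition; on this read-out higher numbers stand for weaker inhibition and lower numbers for stronger inhibition. Compound 1 `Cc1cc(-c2ccc(Cl)cc2)cc(=O)o1` gives > 50000 nM, which is a limit and not a number. Compound 2 `CCc1cc(C)oc(=O)c1` gives > 50000 nM, again a limit. Compound 3 `CCCCCC/C=C/c1cc(C)oc(=O)c1` gives > 50000 nM, also a limit. Compound 1 therefore stands with the other two at the limit of > 50000 nM in this assay, at which 3 of the 3 values shown sit, so no true number is available for comparison.

Compound 4 `COc1ccc(-c2cc(C)oc(=O)c2)cc1` keeps the core of compound 1 and changes one group: methoxy in place of chloro on an aromatic carbon, (methoxy in place of chloro on an aromatic carbon). Going by the values given here, no measured step exists to show what such a change does in this assay. Among the compounds with values here, the only guide is the limit that compound 1 gives, > 50000 nM. A step no larger than the usual scatter is therefore expected, and another limit is the likeliest result. In numbers, the expected move is a number no higher from compound 1 to compound 4 (the limit leaves the size open). For compound 4 the estimated value is 50000 nM, with an expected range from 20000 nM to 100000 nM.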

Compound 4, half-maximal inhibitory concentration: > 50000 nM
Compound 4: a limit, no number (the forecaster's own chance of this, stated with the estimate: 85%); the middle value sits exactly at the limit.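

In this assay compound 4 gives > 50000 nM as a limit and not a number. Going by these compounds alone, no step from compound 1 to compound 4 can be read: (the limit of > 50000 nM in this assay, at which 4 of the 4 values shown sit). As far as these compounds go, whether methoxy in place of chloro on an aromatic carbon changes inhibition at all stays open.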